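The compounds below may be only part of what the source reports. "The series", "measured", "known", "first", "only" and "open" are said of these compounds alone.

In a functional assay on MCF7 cells (Homo sapiens) for cytotoxicity, read by sulforhodamine B assay, with a stated time of 24 h (on this read-out higher numbers stand for weaker inhibition and lower numbers for stronger inhibition), compound 1 (`N#CCC(=O)N/N=C1\C(=O)Nc2ccc(S(=O)(=O)N3CCOCC3)cc21`) gives 27700 nM, compound 2 (`O=C1Nc2ccc(S(=O)(=O)N3CCOCC3)cc2/C1=N/c1ccc(O)cc1`) gives 52700 nM and compound 3 (`O=C1Nc2ccc(S(=O)(=O)N3CCOCC3)cc2/C1=N/c1cccc(C(F)(F)F)c1`) gives 41100 nM on the same read-out. Compound 1 stands level with the other two, not apart from them. Compound 4 (`Cc1ccc(S(=O)(=O)N/N=C2\C(=O)Nc3ccc(S(=O)(=O)N4CCOCC4)cc32)cc1`) departs from compound 1 at one place: (4-methylphenyl)sulfonyl in place of (cyanomethyl)carbonyl on an amine nitrogen. Going by the values given here, no measured step changes that amine nitrogen. The closest evidence lies at the double-bonded nitrogen, with a 1.9-fold higher number from compound 1 to compound 2 (0.28 log units; within the scatter), a 1.5-fold higher number from compound 1 to compound 3 (0.17 log units; within the scatter) and a 1.3-fold lower number from compound 2 to compound 3 (0.11 log units; within the scatter), all within the scatter. No step beyond the scatter is therefore expected in this assay. The expected step is a 1.2-fold higher number from compound 1 to compound 4 (0.06 log units; within the scatter). Compound 4 is estimated at 32000 nM, with an expected range from 13000 nM to 75000 nM.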

Compound 4, half-maximal inhibitory concentration: 38400 nM
Compound 4: middle estimate off by 1.2-fold (0.08 log units), on the low side, within the range that was stated.
By their numbers in this assay, from the lowest: compounds 1, 4, 3 and 2 (each within the scatter of the next).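

Going by these compounds alone, at the amine nitrogen, the first measured change at this place gives a 1.4-fold higher number from compound 1 to compound 4 (0.14 log units; within the scatter) in this assay. The (4-methylphenyl)sulfonyl group, with more heavy atoms and an aromatic ring, is therefore tolerated in place of (cyanomethyl)carbonyl, and the nitrile of compound 1 is not needed to hold the number at this level. No evidence on hand bears on this result. Open, as far as these compounds go, is whether acetyl, benzoyl or a chain ending in a carboxylic acid on this nitrogen would give a step beyond the scatter.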